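This account rests on a few compounds, and the source may have more. Where it says the series, first, only, none or still open, it means among the compounds named here.

Working notes on the series. In a functional assay on KYSE-450 cells (Homo sapiens) for inhibition, read by MTT assay, with a stated time of 48 h (on this read-out lower numbers stand for stronger inhibition and higher numbers for weaker inhibition), compound 1 (`C#CC(=O)N(Cc1ccc(OC)c(O)c1)c1cc(OC)c(OC)c(OC)c1`) gives 570 nM and compound 2 (`CC/C=C/C(=O)N(Cc1ccc(OC)c(O)c1)c1cc(OC)c(OC)c(OC)c1`) gives 72 nM. Among the measured compounds shown here, compound 2 therefore holds the lower of the two numbers so far, and the gap between them lies beyond the scatter.

Compound 3 (`COc1ccc(CN(C(=O)CCl)c2cc(OC)c(OC)c(OC)c2)cc1O`) departs from compound 2 at one place, with chloromethyl in place of but-1-en-1-yl on a carbonyl carbon.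

For the measured compounds named here, only one measured step bears on this change, and it sits on the same carbonyl carbon: a 7.9-fold lower number from compound 1 to compound 2 (0.90 log units; beyond the scatter). That step shows that a change of group here can move the number by a modest amount. It says nothing directly about chloromethyl, which has not yet been tested in this series. Going by the values given here, with compound 2 at 72 nM, the better of only two values, some loss in this assay seems more likely than a gain, though a gain cannot be excluded.

The expected change is a 2.8-fold higher number from compound 2 to compound 3 (0.44 log units; beyond the scatter), a modest step towards a higher number. For compound 3 the estimated value is 200 nM, with an expected range from 40 nM to 1000 nM.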

Compound 3, half-maximal inhibitory concentration: 210 nM
The estimate for compound 3 lay 1.1-fold (0.02 log units) below the measured number; the range from low to high includes it.
By their numbers in this assay, from the lowest: compound 2; then compound 3; then compound 1.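

In this assay, replacing but-1-en-1-yl with chloromethyl on the carbonyl carbon gives a 2.9-fold higher number from compound 2 to compound 3 (0.46 log units; beyond the scatter), while replacing ethynyl with chloromethyl gives a 2.7-fold lower number from compound 1 to compound 3 (0.43 log units; beyond the scatter). This place now has three groups on the shared core, and chloromethyl falls between the other two, with both new steps beyond the scatter, so the number responds to more than a single swap and the earlier pair alone could not show an intermediate case. Nothing available here accounts for this order of the three groups.

The compounds shown leave open whether the difference between compound 2 and compound 3 follows the chlorine, the double bond or the length of the chain, a question that a plain methyl or a saturated butyl chain on the same carbonyl carbon would help to separate. They also leave open whether this order of chloromethyl, ethynyl and but-1-en-1-yl holds on any other core or on any cell line other than the one in this assay.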